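The source may hold more compounds than are shown below. What is called first, only, known or untested is meant among the compounds shown, and "the series" means these compounds.

Measured in an ADME assay on microsomes from liver (Homo sapiens) for metabolic stability, read by LC-MS, using NADPH, with a stated time of 30 min, tested at 0.1 uM; on this read-out higher numbers stand for a more stable compound and lower numbers for a less stable compound:
compound 1 `C[C@@]1(c2cc(NC(=O)c3ncc(C#N)cc3Cl)ccc2F)C=C(CF)OC(N)=N1`: 57%
compound 2 `C[C@@]1(c2cc(NC(=O)c3ncc(OCF)nc3N)ccc2F)C=C(CF)OC(N)=N1`: 67%
compound 3 `C[C@@]1(c2cc(NC(=O)c3ccc(C#N)cn3)ccc2F)C=C(CF)OC(N)=N1`: 88%

Among these three, compound 3 stands highest at 88%, clear of both the others. The next compound to be tested, compound 4 `COc1cnc(C(=O)Nc2ccc(F)c([C@]3(C)C=C(CF)OC(N)=N3)c2)cn1`, keeps the shared core and the amide but differs from compound 3 in one group: 5-methoxypyrazin-2-yl in place of 5-cyanopyridin-2-yl on a carbonyl carbon. In words, a 5-methoxypyrazin-2-yl group takes the place of the 5-cyanopyridin-2-yl group on the carbonyl carbon.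

Among the compounds with values here, no measured compound carries this exact group, so the evidence is indirect. Within the data shown here, the closest comparison is with compound 2, the only measured compound with a pyrazinyl group on that carbonyl carbon, and a number 21 percentage points higher from compound 2 to compound 3 (beyond the scatter). The step of a number 31 percentage points higher from compound 1 to compound 3 (beyond the scatter) shows that compound 3 can also lose much of its standing through a single change on the same ring, whereas a number 10 percentage points higher from compound 1 to compound 2 (within the scatter) separates the two lower compounds.

Compound 3 therefore looks like the high end of this small set, and a modest fall is expected in this assay, an estimated a number 18 percentage points lower from compound 3 to compound 4 (beyond the scatter). For compound 4 the expected value is 70%, with an estimated range of 50% to 87%.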

Compound 4, percent of the compound remaining: 80%
The estimate for compound 4 lay 10 percentage points below the measured number; measured number inside the range.
By their numbers in this assay, from the lowest: compounds 1 and 2 (each within the scatter of the next); then compounds 4 and 3 (each within the scatter of the next).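

In this assay, the result a number 8 percentage points lower from compound 3 to compound 4 (within the scatter) shows that the group on this carbonyl carbon can change from 5-cyanopyridin-2-yl to 5-methoxypyrazin-2-yl without a change beyond the scatter, so a pyrazinyl group here is not tied to the lower number that compound 2 alone had suggested. Compound 4 also stands clear of both earlier lower compounds, with a number 13 percentage points higher from compound 2 to compound 4 (beyond the scatter) and then a number 23 percentage points higher from compound 1 to compound 4 (beyond the scatter) as the two steps, so among these four compounds the two groups carrying a further substituent, 3-chloro-5-cyanopyridin-2-yl and 3-amino-5-(fluoromethoxy)pyrazin-2-yl, go with the lower numbers, and no compound shown goes against this. Nothing available here accounts for these differences.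

The compounds shown leave open whether the ring or its substituent governs the outcome, a question that a 5-methoxypyridin-2-yl or a 5-cyanopyrazin-2-yl group on the same carbonyl carbon would separate. They also leave open how much of the step from compound 2 belongs to the amino group and how much to the fluoromethoxy group, which a 3-amino-5-methoxypyrazin-2-yl group would divide.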